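Phenyl for methyl at the ring carbon of compound 1

The compounds below may be only part of what the source reports. "The series", "measured", "known", "first", "only" and "open" are said of these compounds alone.

Compound 1 `CO[C@@H]1CC=C2NN(c3ccc(C)cc3)C(=O)C[C@]2(C)O1` is the reference of this set. In a functional assay on SK-N-SH cells (Homo sapiens) for inhibition, read by sulforhodamine B assay, with a stated time of 48 h (a higher number here means a weaker inhibitor, a lower number a stronger inhibitor), compound 1 gives 25300 nM. It holds the highest of the three numbers, but none of the others is separated from it beyond the scatter: compound 2 `CO[C@@H]1CC=C2NN(c3cc4ccccc4[nH]3)C(=O)C[C@]2(C)O1` gives 19500 nM, and compound 3 `CO[C@@H]1CC=C2NN(c3cncnc3)C(=O)C[C@]2(C)O1` gives 16600 nM. Within the data shown here, the one step that can be read directly, a 1.5-fold lower number from compound 1 to compound 3 (0.18 log units; within the scatter), concerns the group on the amide-type nitrogen in the ring and stays within the scatter, so the series so far shows no movement at all in this assay.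

Compound 4 `CO[C@@H]1CC=C2NN(c3ccc(C)cc3)C(=O)C[C@]2(c2ccccc2)O1` departs from compound 1 at a different place: phenyl in place of methyl on a saturated ring carbon. Among the measured compounds shown here, no measured pair touches this saturated ring carbon, so neither the step from compound 1 to compound 3 nor the values of compound 2 bear on it; they only show that changes elsewhere left the numbers flat. There is therefore no basis for expecting a step beyond the scatter in either direction, and the expectation for compound 4 stays close to compound 1, with a wide range to reflect the absence of any guiding step.

Compound 4 is estimated at 20000 nM in this assay, within 6000 nM to 70000 nM. That estimate corresponds to an expected step of a 1.3-fold lower number from compound 1 to compound 4 (0.10 log units; within the scatter).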

Compound 4, half-maximal inhibitory concentration: 11100 nM
Compound 4: the middle estimate sits 1.8-fold (0.26 log units) above what was measured; the measured number falls inside the stated range.
By their numbers in this assay, from the lowest: compounds 4, 3, 2 and 1 (each within the scatter of the next, the first and the last beyond it).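

Among these compounds, the saturated ring carbon next to the ring oxygen is the first place where a change carries the number beyond the scatter: in this assay, phenyl in place of methyl gives a 2.3-fold lower number from compound 1 to compound 4 (0.36 log units; beyond the scatter), a modest step. Among the compounds shown here, the change on the amide-type nitrogen, by contrast, gave a 1.5-fold lower number from compound 1 to compound 3 (0.18 log units; within the scatter), so the earlier compounds left it unknown whether any position responds, and this one does, with a six-membered aromatic ring of carbon only accepted here in place of a single methyl carbon without a rise in the number. Nothing available explains this step, and a single pair cannot separate the effect of added size from that of the aromatic ring itself.

From the compounds shown here alone, whether an ethyl or a saturated cyclohexyl at this carbon would give a step of similar size remains open, as does the outcome for a phenyl carrying an amine or a carboxylic acid. Also open, going by these compounds, is whether phenyl at this carbon and pyrimidin-5-yl on the amide-type nitrogen would together lower the number further than phenyl alone.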